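Chloro for methoxy on the pyridine of a thiourea series

The source may report more compounds than this note shows. Statements on the series, on what has been measured and on what is new or still open speak of the compounds shown alone.

Measured so far: compound 1 `FC(F)(F)Oc1ccc(Oc2ccnc(N3CCC(NC(=S)Nc4cccnc4)CC3)c2Cl)cc1Cl`, 33 nM; compound 2 `COc1ccnc(N2CCC(NC(=S)Nc3cccnc3)CC2)c1`, > 5000 nM; compound 3 `FC(F)(F)c1cccc(N2CCC(NC(=S)Nc3cccnc3)CC2)n1`, 630 nM.

In an assay on membranes from brain for binding affinity to Lysophosphatidylserine lipase ABHD12 (Mus musculus), read by fluorescence, with a stated time of 20 min (a higher number here means a weaker inhibitor, a lower number a stronger inhibitor), compound 1 gives 33 nM. Compound 3 gives 630 nM in this assay. For compound 2 the value in this assay is only a limit, > 5000 nM, so compound 2 sits at the limit of > 5000 nM in this assay, at which 1 of the 3 values shown sits, and its true potency is not known beyond that.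

Compound 4 `S=C(Nc1cccnc1)NC1CCN(c2cc(Cl)ccn2)CC1` has not yet been measured. It differs from compound 2 in one place: chloro in place of methoxy on an aromatic carbon. Within the data shown here, compound 1 carries chloro on the same ring, but with a further large group, so no clean step to compare is available. Compound 4 is expected to remain weak, with a step of an at least 1.6-fold lower number from compound 2 to compound 4 (0.22 log units; that floor lies within the scatter) that may not exceed the scatter. The estimate for compound 4 is 3000 nM, between 700 nM and 12000 nM.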

Compound 4, half-maximal inhibitory concentration: 2100 nM
For compound 4 the middle estimate is 1.4-fold (0.15 log units) above the measured one, within the range that was stated.
By their numbers in this assay, from the lowest: compound 1; then compound 3; then compound 4. At a limit, above all of these: compound 2.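

Chloro in place of methoxy, opposite the ring nitrogen, gives the first one-place comparison here: in this assay the change gives an at least 2.3-fold lower number from compound 2 to compound 4 (0.37 log units; beyond the scatter). Chloro is thus the better of these two groups at this position, by a step beyond the scatter. That step is only a floor, and its true size stays unknown, as the value of compound 2 is a limit: the limit of > 5000 nM in this assay, at which 1 of the 4 values shown sits.

The compounds shown leave open how a fluoro, a methyl or an amine would fare at this place. They also leave open whether the same change would carry over to compounds with a further large group on the ring.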